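Chloro to Methoxy: Expecting a Fourth Cytotoxic Analogue

A few compounds are considered here, and "the series" means these few. Any claim that something is new, unique, unknown or untested is made for them only; others in the source may bear on it.

Compound 1, `O=C(Nc1nc2ccccc2s1)c1cn(-c2ccccc2)nc1-c1ccc(Cl)cc1`, in a functional assay on A549 cells (Homo sapiens) for cytotoxicity, read by MTT assay, with a stated time of 72 h (a higher number here means a weaker inhibitor, a lower number a stronger inhibitor), gives 10300 nM.
Compound 2, `O=C(Nc1nc2ccc(Cl)cc2s1)c1cn(-c2ccccc2)nc1-c1ccc(Cl)cc1`, in this assay gives 4360 nM.
Compound 3, `COc1ccc2nc(NC(=O)c3cn(-c4ccccc4)nc3-c3ccc(Cl)cc3)sc2c1`, in this assay gives 31400 nM.

Compound 4, `COc1ccc(-c2nn(-c3ccccc3)cc2C(=O)Nc2nc3ccccc3s2)cc1`, has not yet been measured. It differs from compound 1 by methoxy in place of chloro on an aromatic carbon. The same kind of change separates compound 2 from compound 3, (methoxy in place of chloro on an aromatic carbon), and there it made a step of a 7.2-fold higher number from compound 2 to compound 3 (0.86 log units; beyond the scatter). The two places are not the same, though: in compound 2 the carbon belongs to a ring that is part of a fused or bridged system of two rings, meta to a fused ring and para to a fused ring, whereas in compound 1 it belongs to a ring of carbon only, para to a large group. The cores of compound 1 and compound 2 also differ, by hydrogen in place of chloro on an aromatic carbon, a change that made a step of a 2.4-fold lower number from compound 1 to compound 2 (0.37 log units; beyond the scatter). For the measured compounds named here, with only one prior example, and at a different place, compound 4 is expected to show a step of a 2.1-fold higher number from compound 1 to compound 4 (0.33 log units; beyond the scatter), smaller than the one seen because a 7.2-fold higher number from compound 2 to compound 3 (0.86 log units; beyond the scatter) was made on the other ring. Compound 4 is therefore estimated at 22000 nM, with a likely range from 8000 nM to 60000 nM.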

Compound 4, half-maximal inhibitory concentration: 13700 nM
Compound 4: the middle estimate sits 1.6-fold (0.21 log units) above what was measured; the measured number falls inside the stated range.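

In this assay, the swap from 4-chlorophenyl to 4-methoxyphenyl gives a 1.3-fold higher number from compound 1 to compound 4 (0.12 log units; within the scatter), so on this core, replacing chloro with methoxy makes no difference that can be told apart from ordinary repeat-to-repeat variation. The same written change therefore does not carry over from one core to the other as a step of fixed size, as the two examples show: the same change on two cores in this assay, a 7.2-fold higher number (0.86 log units; beyond the scatter) from compound 2 to compound 3 and a 1.3-fold higher number (0.12 log units; within the scatter) from compound 1 to compound 4, 5.4-fold (0.73 log units) apart, beyond the scatter of two such steps

What this does not show is the reason for the gap, since the two examples differ both in their cores and in which ring carries the change, and a pair of examples cannot separate those two differences.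

The compounds shown leave open whether methoxy would behave the same way on the 4-chlorophenyl position of the core of compound 2, where the other ring also bears a chloro group. They also leave open what an amine or a carboxylic acid would do on that aromatic carbon, para to a large group.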